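The source may report more compounds than this note shows. Statements on the series, on what has been measured and on what is new or still open speak of the compounds shown alone.

Compound 1 `Nc1nc(-c2ccc(OCCO)cc2)cn2c(=O)n(-c3ccccc3)nc12` and compound 2 `Nc1nc(-c2ccc(OCCCl)cc2)cn2c(=O)n(-c3ccccc3)nc12` share one core. In an assay on CHO cells for displacement of a labelled ligand from adenosine receptor A3 (Homo sapiens) (on this read-out higher numbers stand for weaker inhibition and lower numbers for stronger inhibition), compound 1 gives only a limit, > 30000 nM. In this assay compound 2 likewise gives only a limit, > 30000 nM. The step that the two limits leave unreadable from compound 1 to compound 2 therefore cannot be read, both values resting at the limit of > 30000 nM in this assay, at which 2 of the 2 values shown sit. Compound 3 `Nc1nc(-c2ccc(OCC(O)CO)cc2)cn2c(=O)n(-c3ccccc3)nc12` is not yet measured. Relative to compound 2 it carries 1,2-dihydroxyethyl in place of chloromethyl on a saturated chain carbon bound to an oxygen on an aromatic ring. Within the data shown here, the only measured step is the unreadable one, so no size can be drawn from it for the change to compound 3; all that is known is that both measured values sit at the limit. On that basis compound 3 is expected to give a value near the same limit, estimated at 40000 nM, with a range from 10000 nM to 200000 nM. The step that the limit leaves unreadable from compound 2 to compound 3 that this estimate implies is expected to stay within scatter, most likely reported again only as a limit.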

Compound 3, inhibition constant: 1770 nM
The estimate for compound 3 lay 23-fold (1.35 log units) above the measured number, outside the stated range (below it).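

In this assay, among these compounds, the 2,3-dihydroxypropoxy chain of compound 3 gives the first readable number, and replacing chloromethyl with 1,2-dihydroxyethyl on the saturated chain carbon gives an at least 16-fold lower number from compound 2 to compound 3 (1.22 log units; beyond the scatter). The position is therefore not silent to every change, and hydroxymethyl in place of hydrogen on a saturated chain carbon of the hydroxy-bearing chain gives an at least 16-fold lower number from compound 1 to compound 3 (1.22 log units; beyond the scatter), so the hydroxy-ended chain of compound 1 alone does not produce a readable number. Both sizes are lower bounds only, because the steps start from compound 1 and compound 2, each of which gives only a limit: the limit of > 30000 nM in this assay, at which 2 of the 3 values shown sit.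

With one readable number, the series gives no trend at this position. Open, going by these compounds, is whether an amine, a carboxylic acid or a longer chain carrying hydroxy groups at this place would give a lower or higher number than compound 3.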